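This account rests on a few compounds, and the source may have more. Where it says the series, first, only, none or still open, it means among the compounds named here.

Compound 1 `O=C(O)c1cccc(NC(=O)c2ccc(Oc3ccccc3)cc2)c1` — in an assay on isolated protein for agonist activity at Bile acid receptor (Homo sapiens), read by TR-FRET, with a stated time of 3 h, in the absence of a further agent (on this read-out higher numbers stand for an effect only at larger amounts of compound and lower numbers for an effect already at smaller amounts), compound 1 gives 97 nM.
Compound 2 `CC(Oc1cccc(NC(=O)c2ccc(Oc3ccccc3)cc2)c1)C(=O)O` — in this assay compound 2 is recorded as the assay limit > 10000 nM.

Compound 2 thus stands at the limit rather than at a number, the point marked by the limit of > 10000 nM in this assay, at which 1 of the 2 values shown sits. Compound 3 `CC(C)(Oc1cccc(NC(=O)c2ccc(Oc3ccccc3)cc2)c1)C(=O)O` differs from compound 2 by methyl in place of hydrogen on a saturated chain carbon bound to a carbonyl carbon, an oxygen on an aromatic ring and a saturated chain carbon. Going by the values given here, the one measured step that bears on this region is an at least 100-fold higher number from compound 1 to compound 2 (2.01 log units; beyond the scatter), which carried the series to the limit. Among the compounds with values here, no measured pair tells what a further methyl on that chain carbon does. Since compound 2 already sits at the limit, compound 3 is expected to remain there, and the expected step of a number no higher from compound 2 to compound 3 (the limit leaves the size open) is none beyond the scatter. Compound 3 is estimated at 10000 nM, within 2000 nM to 30000 nM.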

Compound 3, half-maximal effective concentration: > 10000 nM
Compound 3: no number, only a limit; the forecaster's own chance of this, stated with the estimate: 80%; the middle value sits exactly at the limit.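

Compound 3 is recorded in this assay as the assay limit > 10000 nM, which is a limit and not a number. The 1-carboxy-1-methylethoxy group, like 1-carboxyethoxy, therefore gives a large change in place of carboxy on an aromatic carbon, with an at least 100-fold higher number from compound 1 to compound 3 (2.01 log units; beyond the scatter). What methyl in place of hydrogen does on the chain carbon cannot be read, as both compounds with these groups stand at the limit: the limit of > 10000 nM in this assay, at which 2 of the 3 values shown sit.

From the compounds shown here alone, whether any acid chain linked through oxygen at this aromatic carbon gives a measurable value stays open. A carboxymethoxy group or the longer 2-carboxyethoxy chain could test this.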